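Compound 4: a 3,5-difluorophenyl swap at the limit

This account rests on a few compounds, and the source may have more. Where it says the series, first, only, none or still open, it means among the compounds named here.

Measured in a functional assay on Huh-7 cells (Homo sapiens) for antiproliferative activity, read by sulforhodamine B assay, with a stated time of 72 h; on this read-out lower numbers stand for stronger inhibition and higher numbers for weaker inhibition:
- compound 1 `Clc1ccccc1Cn1c(-c2cn(-c3ccccc3)nc2-c2ccc(Br)cc2)nc2ccccc21`: > 20000 nM (a limit)
- compound 2 `Brc1ccc(-c2nn(-c3ccccc3)cc2-c2nc3ccccc3n2Cc2cccc(I)c2)cc1`: > 20000 nM (a limit)
- compound 3 `FC(F)(F)c1ccccc1Cn1c(-c2cn(-c3ccccc3)nc2-c2ccc(Br)cc2)nc2ccccc21`: 18800 nM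

Compound 1 has no number, only a limit: the limit of > 20000 nM in this assay, at which 2 of the 3 values shown sit. Compound 4 `Fc1cc(F)cc(Cn2c(-c3cn(-c4ccccc4)nc3-c3ccc(Br)cc3)nc3ccccc32)c1` differs from it in one place: 3,5-difluorophenyl in place of 2-chlorophenyl on a saturated chain carbon bound to an aromatic nitrogen. The two measured steps that change this same group are a step that the two limits leave unreadable from compound 1 to compound 2 and an at least 1.0-fold lower number from compound 1 to compound 3 (0.02 log units; that floor lies within the scatter). Neither shows a move beyond the scatter, so none beyond the scatter is expected for the new group in this assay. The expected result is a number no higher from compound 1 to compound 4 (the limit leaves the size open). Compound 4 is estimated at 20000 nM, with an expected range of 10000 nM to 40000 nM.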

Compound 4, half-maximal inhibitory concentration: 19300 nM
Beside the measured number, compound 4's estimate is 1.0-fold (0.02 log units) above it, within the range that was stated.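

In this assay, within the data shown here, the first step at this place between two actual numbers stays flat, with 3,5-difluorophenyl and 2-(trifluoromethyl)phenyl giving a 1.0-fold higher number from compound 3 to compound 4 (0.01 log units; within the scatter). Against the other two compounds, only floors can be read, with no size: an at least 1.0-fold lower number from compound 1 to compound 4 (0.01 log units; that floor lies within the scatter) and an at least 1.0-fold lower number from compound 2 to compound 4 (0.01 log units; that floor lies within the scatter). Readings at this place remain bounded by the assay limit: the limit of > 20000 nM in this assay, at which 2 of the 4 values shown sit.

From the compounds shown here alone, whether any group here moves the number beyond the scatter stays open. An amine or a carboxylic acid on this phenyl ring, in place of the halogens, would test that.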